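A Methoxy Group Joins the Anilino Arm

The compounds below may be only part of what the source reports. "The series", "measured", "known", "first", "only" and "open" are said of these compounds alone.

Measured so far:
compound 1 `Cc1nc(SCC(=O)Nc2nc(-c3ccc(Cl)cc3)cs2)n(Nc2ccccc2)c1C`: 3780 nM
compound 2 `Cc1ccc(Nn2c(SCC(=O)Nc3nc(-c4ccccc4)cs3)nc(C)c2C)cc1`: 4370 nM

Of the compounds shown here, two sharing one core have been tested in a functional assay on HT-29 cells (Homo sapiens) for antiproliferative activity, read by sulforhodamine B assay, with a stated time of 48 h; a higher number here means a weaker inhibitor of growth, a lower number a stronger inhibitor of growth. Compound 1 `Cc1nc(SCC(=O)Nc2nc(-c3ccc(Cl)cc3)cs2)n(Nc2ccccc2)c1C` gives 3780 nM, and compound 2 `Cc1ccc(Nn2c(SCC(=O)Nc3nc(-c4ccccc4)cs3)nc(C)c2C)cc1` gives 4370 nM, the two numbers lying within the usual scatter of each other. Compound 3 `COc1ccc(Nn2c(SCC(=O)Nc3nc(-c4ccc(Cl)cc4)cs3)nc(C)c2C)cc1` awaits measurement in this assay. It differs from compound 1 in one place: methoxy in place of hydrogen on an aromatic carbon. Among the measured compounds shown here, no pair of measured compounds isolates this change, so the step expected is a 1.1-fold lower number from compound 1 to compound 3 (0.02 log units; within the scatter), not beyond the scatter and with no preferred direction. Compound 3 is therefore estimated at 3600 nM, within a range from 1500 nM to 8500 nM.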

Compound 3, concentration for 50% growth inhibition: 4610 nM
Compound 3: the middle estimate sits 1.3-fold (0.11 log units) below what was measured, and the stated range covers the measured number.
By their numbers in this assay, from the lowest: compounds 1, 2 and 3 (each within the scatter of the next).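

Among the compounds shown here, the change from anilino to (4-methoxyphenyl)amino gives the first direct reading at this position: in this assay it amounts to a 1.2-fold higher number from compound 1 to compound 3 (0.09 log units; within the scatter), so on this evidence methoxy in place of hydrogen here produces no step beyond the scatter. The earlier compounds shown here, which differ in more than one place, could not show this. No measurement available here accounts for the result.

As far as these compounds go, whether a hydroxyl group, an amine or a longer chain such as butoxy at this same position would also stay within the scatter remains open.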